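Phenyl in place of iodo: expectation for compound 4

The source may report more compounds than this note shows. Statements on the series, on what has been measured and on what is new or still open speak of the compounds shown alone.

Measured compounds in a functional assay on CCRF-CEM cells (Homo sapiens), read by MTT assay, with a stated time of 72 h; a lower number here means a stronger inhibitor, a higher number a weaker inhibitor:
Compound 1 `Nc1nc(N)c2c(-c3ccsc3)cn([C@@H]3O[C@H](CO)[C@@H](O)[C@H]3O)c2n1`; its result is a limit of the assay, > 20000 nM.
Compound 2 `COc1ncnc2c1c(I)cn2[C@@H]1O[C@H](CO)[C@@H](O)[C@H]1O` gives 1150 nM.
Compound 3 `Nc1nc(N)c2c(-c3ccoc3)cn([C@@H]3O[C@H](CO)[C@@H](O)[C@H]3O)c2n1`; its result is a limit of the assay, > 20000 nM.

Among the compounds with values here, compound 2 is the only compound of the three with an actual number in this assay; the other two values are limits. Within the data shown here, the one measured step, a step that the two limits leave unreadable from compound 1 to compound 3, cannot be read, since both ends of it sit at a limit, as noted by the limit of > 20000 nM in this assay, at which 2 of the 3 values shown sit.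

Compound 4 `COc1ncnc2c1c(-c1ccccc1)cn2[C@@H]1O[C@H](CO)[C@@H](O)[C@H]1O` differs from compound 2 as follows: phenyl in place of iodo on an aromatic carbon. Among the measured compounds shown here, no measured step touches this change. The step from compound 1 to compound 3 concerns a different change and its size is not readable, so it gives no guide to the size or direction of the step in this assay.

For the measured compounds named here, with no bearing step, a step of the size a 1.4-fold lower number from compound 2 to compound 4 (0.16 log units; within the scatter) is expected, within or near the scatter. Compound 4 is estimated at 800 nM, with a range from 200 nM to 4000 nM.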

Compound 4, half-maximal inhibitory concentration: > 20000 nM
Compound 4 gave a limit, no number; the forecaster's own chance of this, stated with the estimate: 10%; middle value at least 25-fold (1.39 log units) away from the limit.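

In this assay, within the data shown here, the change from iodo to phenyl on this aromatic carbon, two ring bonds from the ring nitrogen, gives the first readable step: an at least 17-fold higher number from compound 2 to compound 4 (1.24 log units; beyond the scatter). Compound 4 gives > 20000 nM, which is a limit of the assay and not a number, so this step fixes a direction and a minimum size but no exact size. The earlier step between compound 1 and compound 3 could not be read, so this position is the only one shown where a single change moves a compound from a measured value to the limit, and compound 2 remains the only compound with an actual number: the limit of > 20000 nM in this assay, at which 3 of the 4 values shown sit.

Going by these compounds, with only iodo and phenyl compared on the core of compound 2, it stays open whether the step follows the six-membered aromatic ring itself or simply the larger count of heavy atoms, and a methyl, an ethynyl or an amine at this carbon would help to separate these. On these data alone, it is also open whether a methoxy-bearing core with a five-membered aromatic ring such as furan-3-yl at this carbon would return a number or stay at the limit.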